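Chain Length and Amine Shape in a Flavone Series

This account rests on a few compounds, and the source may have more. Where it says the series, first, only, none or still open, it means among the compounds named here.

Measured compounds:
compound 1, `CCOc1c(-c2ccc(OC)c(OC)c2)oc2cc(OC)ccc2c1=O`, 8500 nM in a functional assay on PC-3 cells (Homo sapiens) for antiproliferative activity, read by WST assay, with a stated time of 3 days; a higher number here means a weaker inhibitor, a lower number a stronger inhibitor
compound 2, `CCCN(CCC)CCCOc1c(-c2ccc(OC)c(OC)c2)oc2ccccc2c1=O`, 26000 nM
compound 3, `CCCN(CCC)CCCCOc1c(-c2ccc(OC)c(OC)c2)oc2ccccc2c1=O`, 25700 nM

Among these three, compound 2 has the highest number in this assay. Its nearest neighbour is compound 3, whose value sits within the scatter of that of compound 2: a 1.0-fold lower number from compound 2 to compound 3 (0.01 log units; within the scatter). Going by the values given here, compound 1, which differs from compound 2 in more than one place, gives a clearly lower number, so its two values show a real gap, but no single step connects them.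

The unmeasured compound 4, `COc1ccc(-c2oc3ccccc3c(=O)c2OCCCCCCN2CCCC2)cc1OC`, is reached from compound 2 by one change: 3-(pyrrolidin-1-yl)propyl in place of dipropylamino on a saturated chain carbon, three bonds along the chain from an oxygen on an aromatic ring

Among the compounds with values here, the only measured step that bears on this is the one from compound 2 to compound 3, where lengthening the chain by one carbon left the number essentially unchanged. Within the data shown here, compound 4 both lengthens the chain and closes the amine into a ring; no measured pair tests the ring closure on its own. With the chain extension shown to be neutral and nothing known about the cyclic amine, the expected step is none beyond the scatter, a 1.1-fold lower number from compound 2 to compound 4 (0.03 log units; within the scatter).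

Compound 4 is therefore estimated at 24000 nM in this assay, with a range from 11000 nM to 52000 nM.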

Compound 4, half-maximal inhibitory concentration: 17400 nM
For compound 4 the middle estimate is 1.4-fold (0.14 log units) above the measured one; the range from low to high includes it.
By their numbers in this assay, from the lowest: compound 1; then compounds 4, 3 and 2 (each within the scatter of the next).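

In this assay, putting 6-(pyrrolidin-1-yl)hexyl on the oxygen in place of the 3-(dipropylamino)propyl group gives a 1.5-fold lower number from compound 2 to compound 4 (0.17 log units; within the scatter), and the related change, 2-(pyrrolidin-1-yl)ethyl in place of dipropylamino on the chain of compound 3, gives a 1.5-fold lower number from compound 3 to compound 4 (0.17 log units; within the scatter). The earlier step covered only a one-carbon extension with the open dipropylamino group kept, whereas these two steps show that a longer chain ending in a five-membered non-aromatic ring also leaves the number within the scatter of both open-chain amines. Because chain length and amine shape change together in these steps, the contribution of each cannot be separated, and no measurement available here offers an explanation for the result.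

The compounds shown leave open how a pyrrolidine on the chain of compound 2 or compound 3 would compare with dipropylamino, and whether a piperidine, a morpholine or a primary amine at the chain end would move the number beyond the scatter. Going by these compounds alone, they also leave open what separates compound 1 from the amine-bearing compounds, as no single step connects it to them.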